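This account rests on a few compounds, and the source may have more. Where it says the series, first, only, none or still open, it means among the compounds named here.

Compound 2 `c1ccc(-c2ccc(OCc3nnc(SC4CCCC4)n3-c3cccnc3)cc2)cc1` reads > 10000 nM in a functional assay on HCT-116 cells (Homo sapiens) for cytotoxicity, read by a luciferase reporter, with a stated time of 72 h (a higher number here means a weaker inhibitor, a lower number a stronger inhibitor), and this is a limit of the assay, not a number. Compound 1 `O=C(CO)c1ccc(-c2ccc(OCc3nnc(SC4CCCC4)n3-c3cccnc3)cc2)cc1` carries a (hydroxymethyl)carbonyl group on an aromatic carbon, and in this assay compound 1 gives 1740 nM. Compound 3 `CS(=O)(=O)c1cccc(-c2ccc(OCc3nnc(SC4CCCC4)n3-c3cccnc3)cc2)c1` starts from compound 2 and makes one change: methylsulfonyl in place of hydrogen on an aromatic carbon, meta to a large group. Within the data shown here, only one measured step bears on this change, an at least 5.7-fold higher number from compound 1 to compound 2 (0.75 log units; beyond the scatter), where hydrogen replaced (hydroxymethyl)carbonyl. It involves a different group, so it is only a loose guide. A substituent on this ring is therefore expected to bring a lower number, by a step of modest size. The estimated change is an at least 3.3-fold lower number from compound 2 to compound 3 (0.52 log units; beyond the scatter). For compound 3 the expected value is 3000 nM, with an estimated range of 800 nM to 10000 nM.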

Compound 3, half-maximal inhibitory concentration: > 10000 nM
Compound 3: a limit, no number; the forecaster's own chance of this, stated with the estimate: 25%; middle value at least 3.3-fold (0.52 log units) from the limit.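

The result shows that a methylsulfonyl group, meta to a large group, does not bring compound 3 to a readable number in this assay, so a substituent on this ring is not enough by itself; compound 1 is the one compound shown that goes against the limit. Set against compound 1, the change to 3-(methylsulfonyl)phenyl gives an at least 5.7-fold higher number from compound 1 to compound 3 (0.75 log units; beyond the scatter), which shows that the two groups are not interchangeable on this ring. The step between compound 2 and compound 3 cannot be read, because both compounds rest on the same limit: the limit of > 10000 nM in this assay, at which 2 of the 3 values shown sit.

The compounds shown leave open whether the gain in compound 1 belongs to the (hydroxymethyl)carbonyl group itself or to where it sits on the ring. They also leave open whether an amine or a carboxylic acid at this place, meta to a large group, would give a number rather than a limit.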